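The source may hold more compounds than are shown below. What is called first, only, known or untested is meant among the compounds shown, and "the series" means these compounds.

Values in an in vitro ADME assay on microsomes from liver (Homo sapiens) for metabolic stability; a lower number here means slower removal, a higher number faster removal of the compound:
compound 1 `Cc1nnc(C2CCN(c3ccccn3)CC2)n1Cc1ccccc1`: < 8 mL.min-1.g-1 (a limit of the assay)
compound 2 `CCOCc1nnc(C2CCN(c3ccccn3)CC2)n1Cc1ccccc1`: 23 mL.min-1.g-1

Going by the values given here, compound 2 holds the only actual number so far. Compound 3 `O=C(O)COCc1nnc(C2CCN(c3ccccn3)CC2)n1Cc1ccccc1` is derived from it by carboxy in place of methyl on a saturated chain carbon bound to an oxygen on a saturated carbon, with carboxy in place of methyl on a saturated chain carbon bound to an oxygen on a saturated carbon. Among the compounds with values here, the one measured step is an at least 2.8-fold higher number from compound 1 to compound 2 (0.45 log units; beyond the scatter), with ethoxy in place of hydrogen on a saturated chain carbon bound to an aromatic carbon. It bears only loosely, as the new change alters that same ethoxy. A modest fall in this assay is therefore expected. The estimated step is a 2.9-fold lower number from compound 2 to compound 3 (0.46 log units; beyond the scatter). Compound 3 is expected at 8 mL.min-1.g-1, within an estimated range of 4 mL.min-1.g-1 to 16 mL.min-1.g-1.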

Compound 3, intrinsic clearance in microsomes: < 8 mL.min-1.g-1
Compound 3: only a limit was reported; the forecaster's own chance of this, stated with the estimate: 60%; the middle value sits exactly at the limit.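

In this assay, exchanging ethoxy for carboxymethoxy on the same chain gives an at least 2.8-fold lower number from compound 2 to compound 3 (0.45 log units; beyond the scatter). The higher number seen with ethoxy therefore does not hold for every ether chain at this position, and the end of the chain matters. The step between compound 1 and compound 3 cannot be read, because both values are limits: the limit of < 8 mL.min-1.g-1 in this assay, at which 2 of the 3 values shown sit.

From the compounds shown here alone, whether an amine, an amide or a longer chain in place of the carboxy group would also give a low number stays open. Going by these compounds, how far compound 3 really lies from its limit stays open too.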